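Replacing the aminophenyl ketone in a chalcone-type pyrazole series

The source may hold more compounds than are shown below. What is called first, only, known or untested is meant among the compounds shown, and "the series" means these compounds.

The account concerns a small series of compounds built on a shared core, an enone linking a pyrazole to an aryl ketone. Compound 1 `COc1ccc(-c2cc(/C=C/C(=O)c3ccc(N)cc3)[nH]n2)cc1` carries a single methoxy group on the pyrazole-bound ring, and compound 2 `COc1cc(-c2cc(/C=C/C(=O)c3ccc(N)cc3)[nH]n2)cc(OC)c1OC` carries three. In a functional assay on MDA-MB-468 cells (Homo sapiens) for inhibition, read by sulforhodamine B assay, with a stated time of 48 h (on this read-out higher numbers stand for weaker inhibition of growth and lower numbers for stronger inhibition of growth), compound 1 gives 2090 nM, and in this assay compound 2 gives 2910 nM. These two numbers lie within the usual scatter of each other, so compound 2 stands alongside compound 1 rather than apart from it, and no difference between the two can be read from them.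

Compound 3 `COc1cc(-c2cc(/C=C/C(=O)c3ccc(Cl)c(Cl)c3)[nH]n2)cc(OC)c1OC` keeps the trimethoxy side of compound 2 and alters the ketone side: 3,4-dichlorophenyl in place of 4-aminophenyl on a carbonyl carbon. Among the compounds with values here, no measured pair shows the effect of such a change, so nothing here tells which way it should move the number. The step from compound 2 to compound 3 is therefore expected to be small, with a 1.1-fold lower number from compound 2 to compound 3 (0.05 log units; within the scatter) lying within the scatter in either direction. Compound 3 is accordingly estimated at 2600 nM, with a plausible range from 600 nM to 11000 nM.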

Compound 3, concentration for total growth inhibition: 7220 nM
Estimate against measurement, compound 3: 2.8-fold (0.44 log units) below, and the stated range covers the measured number.
By their numbers in this assay, from the lowest: compounds 1 and 2 (each within the scatter of the next); then compound 3.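

With compound 3 the series gains its first readable step on the ketone side. In this assay the change to 3,4-dichlorophenyl in place of 4-aminophenyl on a carbonyl carbon gives a 2.5-fold higher number from compound 2 to compound 3 (0.39 log units; beyond the scatter) and so means weaker inhibition of growth, though the step is modest. Within the data shown here, compounds 1 and 2, which differ only on the pyrazole-bound ring, could not be told apart from each other, so this is the first change that moves the number beyond the scatter, and nothing available accounts for the shift.

Among these compounds, the result rests on one pair with the trimethoxy side in place, so it remains open whether the same exchange would move the number in the same way with the single methoxy group of compound 1. On these data alone, it is also open whether the shift goes with the loss of the amine or the arrival of the chlorines, a question that a 4-chlorophenyl, 4-hydroxyphenyl or 4-carboxyphenyl group on the same carbonyl carbon could help to separate.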